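A few compounds are considered here, and "the series" means these few. Any claim that something is new, unique, unknown or untested is made for them only; others in the source may bear on it.

Compound 3 `CCc1cccc2c(OC)c(-c3occ(C)c3COC)ccc12` gives 9.7 ug/mL in a functional assay on MDA-MB-231 cells (Homo sapiens) for cytotoxicity, read by MTT assay, with a stated time of 72 h (a higher number here means that more compound is needed for the effect, a lower number that less compound is needed), the highest of the two numbers shown; the nearest is compound 2 `CCOc1c(-c2occ(C)c2C(=O)OC)ccc2c(CC)cccc12`, which gives 1.2 ug/mL. Compound 1 `CCOc1c(-c2occ(C)c2C(=O)O)ccc2c(CC)cccc12` gives only a limit, > 10 ug/mL (the limit of > 10 ug/mL in this assay, at which 1 of the 3 values shown sits). Going by the values given here, the single measured step, an at least 8.3-fold lower number from compound 1 to compound 2 (0.92 log units; beyond the scatter), sits on the oxygen next to a carbonyl group and does not touch the place changed here. Compound 4 `CCOc1c(-c2occ(C)c2COC)ccc2c(CC)cccc12` differs from compound 3 by methyl in place of hydrogen on a saturated chain carbon bound to an oxygen on an aromatic ring. Among the compounds with values here, no measured step bears on this change, so no movement beyond the scatter is expected in this assay. For compound 4 the expected value is 9 ug/mL, within 3 ug/mL to 25 ug/mL. This amounts to an expected step of a 1.1-fold lower number from compound 3 to compound 4 (0.03 log units; within the scatter) for compound 4.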

Compound 4, concentration for half-maximal effect: > 10 ug/mL
Compound 4 was reported as a limit; the forecaster's own chance of this, stated with the estimate: 40%; middle value at least 1.1-fold (0.04 log units) from the limit.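

Compound 4 stands at a limit, not a number, in this assay: the limit of > 10 ug/mL in this assay, at which 2 of the 4 values shown sit.

Ethoxy in place of methoxy gives only an at least 1.0-fold higher number from compound 3 to compound 4 (0.01 log units; that floor lies within the scatter), so this floor does not establish a change at this position. With ethoxy held constant, methoxymethyl in place of methoxycarbonyl on an aromatic carbon gives an at least 8.3-fold higher number from compound 2 to compound 4 (0.92 log units; beyond the scatter); the step between compound 1 and compound 4 cannot be read.

Going by these compounds, the size of the methyl effect on the saturated chain carbon stays open. So does the outcome with a longer chain such as propoxy there, or with an amide in place of methoxycarbonyl.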